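Amide carbocycle variation on the fluorophenyl oxadiazole azetidine series

The compounds below may be only part of what the source reports. "The series", "measured", "known", "first", "only" and "open" are said of these compounds alone.

Compound 3 `O=C(C1CCCCC1)N1CC(c2nc(-c3cccc(F)c3)no2)C1` gives 1000 nM in an assay on HEK293 cells for positive allosteric modulation of metabotropic glutamate receptor 5 (Homo sapiens), read by FLIPR (on this read-out lower numbers stand for an effect already at smaller amounts and higher numbers for an effect only at larger amounts of compound), the second highest of the three numbers measured. Compound 1 `O=C(c1ccc(Cl)cc1)N1CC(c2nc(-c3cccc(F)c3)no2)C1` gives 2500 nM in this assay, and compound 2 `O=C([C@H]1CC2CCC1C2)N1CC(c2nc(-c3ccccc3)no2)C1` gives 120 nM. Compound 2 differs from compound 3 in two places, so its lower number cannot be assigned to one change alone. Within the data shown here, the only single step measured on the carbonyl carbon is a 2.5-fold lower number from compound 1 to compound 3 (0.40 log units; beyond the scatter). Compound 4 `O=C([C@H]1CC2CCC1C2)N1CC(c2nc(-c3cccc(F)c3)no2)C1` carries a group of 7 heavy atoms (7 carbon; 2 five-membered non-aromatic rings of carbon only) in place of a group of 6 heavy atoms (6 carbon; one six-membered non-aromatic ring of carbon only), on a carbonyl carbon. Compound 4 shares its bicyclic amide with compound 2, whose number in this assay is 120 nM. Compound 4 is therefore expected to give 300 nM in this assay, between 100 nM and 1000 nM, a step of a 3.3-fold lower number from compound 3 to compound 4 (0.52 log units; beyond the scatter).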

Compound 4, half-maximal effective concentration: 72 nM
The estimate for compound 4 lay 4.2-fold (0.62 log units) above the measured number, and the stated range ends above it.
By their numbers in this assay, from the lowest: compounds 4 and 2 (each within the scatter of the next); then compound 3; then compound 1.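

With the rest of the molecule unchanged, the group with 2 five-membered non-aromatic rings of carbon only, in place of cyclohexyl, gives a 14-fold lower number from compound 3 to compound 4 (1.14 log units; beyond the scatter) in this assay and so carries a large gain on its own. In place of 4-chlorophenyl, the same group gives a 35-fold lower number from compound 1 to compound 4 (1.54 log units; beyond the scatter) on the same carbonyl carbon. Fluoro in place of hydrogen on an aromatic carbon gives a 1.7-fold lower number from compound 2 to compound 4 (0.22 log units; within the scatter) and adds no separable change.

On these data alone, whether an amine or a carboxylic acid on this carbocycle keeps the number stays open. No evidence at hand explains the step from cyclohexyl.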